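A few compounds are considered here, and "the series" means these few. Any claim that something is new, unique, unknown or untested is made for them only; others in the source may bear on it.

Measured so far:
- compound 1, `C=CCOc1cc(/C=C/C(=O)c2ccc(OC)c3c2OC(C)(C)C=C3)ccc1OC`: > 20000 nM
- compound 2, `COc1ccc(/C=C/C(=O)c2ccc(OC)c3c2OC(C)(C)C=C3)cc1OCCCN(C)C`: 8600 nM

In an ADME assay on L02 cells (Homo sapiens) for cytotoxicity, read by MTT assay (on this read-out lower numbers stand for stronger inhibition and higher numbers for weaker inhibition), compound 1 reaches only the assay limit, (the limit of > 20000 nM in this assay, at which 1 of the 2 values shown sits), so no number is known for it. Compound 2 gives 8600 nM, and an at least 2.3-fold lower number from compound 1 to compound 2 (0.36 log units; beyond the scatter). Compound 3, `COc1ccc(/C=C/C(=O)Oc2cc(/C=C/C(=O)c3ccc(OC)c4c3OC(C)(C)C=C4)ccc2OC)cc1`, is not yet measured. It differs from compound 1 by (2-(4-methoxyphenyl)ethenyl)carbonyl in place of allyl on an oxygen on an aromatic ring. Within the data shown here, the single measured step, from compound 1 to compound 2, changes a different group at the same oxygen on the aromatic ring and so bears only loosely on this step; it shows that a change at this oxygen can move the number out of the limit region, but gives no direction for the (2-(4-methoxyphenyl)ethenyl)carbonyl group. For compound 3 no step beyond the scatter is expected, and the estimate is 20000 nM, range 6000 nM to 60000 nM, which means a number no higher from compound 1 to compound 3 (the limit leaves the size open).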

Compound 3, half-maximal inhibitory concentration: 18000 nM
Compound 3: the middle estimate sits 1.1-fold (0.05 log units) above what was measured; measured number inside the range.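

In this assay the oxygen on the aromatic ring now carries (2-(4-methoxyphenyl)ethenyl)carbonyl, and this large group gives a measured number where allyl gave none (an at least 1.1-fold lower number from compound 1 to compound 3 (0.04 log units; that floor lies within the scatter)). Set against 3-(dimethylamino)propyl at the same oxygen, the group stands modestly higher on the read-out (a 2.1-fold higher number from compound 2 to compound 3 (0.32 log units; beyond the scatter)), so the two measured groups at this position can now be ordered. The step from allyl has no fixed size, and compound 1 remains a limit, not a number: the limit of > 20000 nM in this assay, at which 1 of the 3 values shown sits.

The compounds shown leave open whether the lower number of compound 2 follows the terminal dimethylamino group or the chain carrying it; a morpholine or a shorter amine chain on this oxygen would separate the two. As far as these compounds go, how a carboxylic acid at this oxygen would read also stays open.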